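The source may hold more compounds than are shown below. What is called first, only, known or untested is meant among the compounds shown, and "the series" means these compounds.

Measured compounds: compound 1 `Cc1c(OCCCCOc2ccc(C(=O)O)cc2)ccc(C(=O)CC(C)C)c1O`, where in an assay on HEK293 cells for positive allosteric modulation of metabotropic glutamate receptor 3 (Rattus norvegicus), read by thallium flux, with a stated time of 2.5 min (a lower number here means that less compound is needed, a higher number that more compound is needed for the effect), compound 1 gives 2720 nM; compound 2 `CCC(=O)c1ccc(OCCCCOc2ccc(F)c(C(=O)O)c2)c(C)c1O`, where in this assay compound 2 gives "not determined" (no result reported); compound 3 `Cc1c(OCCCCOc2ccc(C(=O)O)cc2)ccc(C(=O)CC(C)C)c1C`, where in this assay compound 3 gives "not determined" (no result reported).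

Among the compounds with values here, compound 1 thus stands as the only entry with a number; compounds 2 and 3 offer nothing to set beside it. Compound 4 `Cc1ccc(C(=O)O)cc1OCCCCOc1ccc(C(=O)CC(C)C)c(O)c1C` differs from compound 1 in one place: 5-carboxy-2-methylphenyl in place of 4-carboxyphenyl on an oxygen on a saturated carbon. Within the data shown here, no step between measured compounds is available to gauge a change of this kind, so the expectation rests on compound 1 alone. The step of a 1.1-fold lower number from compound 1 to compound 4 (0.04 log units; within the scatter) is expected to be none beyond the usual scatter. Compound 4 is accordingly estimated to give 2500 nM in this assay, within a range from 800 nM to 8000 nM.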

Compound 4, half-maximal effective concentration: > 10000 nM
Compound 4: only a limit was reported; the forecaster's own chance of this, stated with the estimate: 15%; middle value at least 4.0-fold (0.60 log units) away from the limit.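

Within the data shown here, for compound 4 the result in this assay is a limit and not a number: the limit of > 10000 nM in this assay, at which 1 of the 4 values shown sits. Even so, 5-carboxy-2-methylphenyl in place of 4-carboxyphenyl gives an at least 3.6-fold higher number from compound 1 to compound 4 (0.56 log units; beyond the scatter), the first step that can be read at this place. The group on this oxygen therefore matters to the result, and the step shows that this change costs rather than holds the effect.

The compounds shown leave open how much of the step belongs to the added methyl and how much to the altered place of the carboxylic acid. They also leave open how a tetrazole or a primary amide in place of the carboxylic acid would read.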